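The source may hold more compounds than are shown below. What is called first, only, known or untested is meant among the compounds shown, and "the series" means these compounds.

The measured compounds:
Compound 1, `O=C(C1CCC2(CCC2)CC1)N1CC(c2nc(-c3cccc(Cl)c3)no2)C1`: in an assay on HEK293 cells for negative allosteric modulation of metabotropic glutamate receptor 5 (Homo sapiens), read by FLIPR (a higher number here means a weaker inhibitor, a lower number a stronger inhibitor), compound 1 gives > 10000 nM, which is a limit of the assay rather than a number.
Compound 2, `COC1CCN(C(=O)N2CC(c3nc(-c4cccc(Cl)c4)no3)C2)CC1`: in this assay compound 2 gives > 10000 nM, also a limit of the assay.
Compound 3, `Cc1cccc(-c2noc(C3CN(C(=O)c4ccccc4F)C3)n2)c1`: in this assay compound 3 gives 1400 nM.

Within the data shown here, compound 3 thus holds the only real number among the three; the other two sit at the limit of > 10000 nM in this assay, at which 2 of the 3 values shown sit. Compound 4, `O=C(c1ccccc1F)N1CC(c2nc(-c3cccc(Cl)c3)no2)C1`, has not yet been measured. It differs from compound 3 in one place: chloro in place of methyl on an aromatic carbon. Among the measured compounds shown here, the only measured step, a step that the two limits leave unreadable from compound 1 to compound 2, concerns the group on the carbonyl carbon, not the aromatic ring, and its size cannot be read from two limits in any case. For the measured compounds named here, no measured step therefore bears on the exchange of chloro for methyl, and no step beyond the usual scatter is expected in this assay in either direction. Compound 4 is accordingly expected to give about 1200 nM in this assay, with a likely range from 400 nM to 4000 nM. That expectation corresponds to a step of a 1.2-fold lower number from compound 3 to compound 4 (0.07 log units; within the scatter).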

Compound 4, half-maximal inhibitory concentration: 670 nM
Beside the measured number, compound 4's estimate is 1.8-fold (0.25 log units) above it, and the stated range covers the measured number.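

In this assay, among these compounds, this is the first reading at this place on the aromatic ring, meta to a large group: chloro in place of methyl gives a 2.1-fold lower number from compound 3 to compound 4 (0.32 log units; beyond the scatter). With the 3-chlorophenyl held constant, the group on the carbonyl carbon also proves to matter, as 2-fluorophenyl in place of 4-methoxypiperidin-1-yl gives an at least 14-fold lower number from compound 2 to compound 4 (1.17 log units; beyond the scatter), and 2-fluorophenyl in place of the all-carbon group with two rings gives an at least 14-fold lower number from compound 1 to compound 4 (1.17 log units; beyond the scatter). Those two steps are minimum sizes and the step between compound 1 and compound 2 cannot be read, since both compounds give a limit of the assay rather than a number: the limit of > 10000 nM in this assay, at which 2 of the 4 values shown sit.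

As far as these compounds go, it remains open how other groups at this ring place, such as bromo or a nitrile, would compare with chloro and methyl. Also open, from the compounds shown here alone, is whether the chloro-for-methyl step would hold with another group on the carbonyl carbon, such as a pyridinyl ring.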